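A Methyl Group Added to Compound 1

The source may hold more compounds than are shown below. What is called first, only, known or untested is meant among the compounds shown, and "the series" means these compounds.

Three compounds have been measured:
compound 1, `COC(=O)[C@@]1(C)CC[C@@H]2C3=C1CC[C@@H](C)[C@]3(C)C[C@@H]1c3ccccc3N[C@H]21`: 35000 nM
compound 2, `COC(=O)[C@@]1(C)CC[C@@H]2C3=C1CC[C@@H](C)[C@]3(C)C[C@@H]1c3cc(Br)ccc3N[C@H]21`: 31000 nM
compound 3, `COC(=O)[C@@]1(C)CC[C@@H]2C3=C1CC[C@@H](C)[C@]3(C)C[C@@H]1c3cc(Cl)ccc3N[C@H]21`: 28000 nM

In a functional assay on T47D cells (Homo sapiens) for inhibition, read by sulforhodamine B assay, with a stated time of 48 h (a higher number here means a weaker inhibitor of growth, a lower number a stronger inhibitor of growth), compound 1 gives the highest of the three numbers, yet its steps to the halogenated compounds, a 1.1-fold lower number from compound 1 to compound 2 (0.05 log units; within the scatter) and a 1.3-fold lower number from compound 1 to compound 3 (0.10 log units; within the scatter), both lie within the scatter, as does a 1.1-fold lower number from compound 2 to compound 3 (0.04 log units; within the scatter). The three values therefore cannot be ordered.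

Compound 4, `COC(=O)[C@@]1(C)CC[C@@H]2C3=C1CC[C@@H](C)[C@]3(C)C[C@@H]1c3cccc(C)c3N[C@H]21`, differs from compound 1 by methyl in place of hydrogen on an aromatic carbon. Among the measured compounds shown here, no measured step introduces a methyl group; the nearest comparisons are the halogen substitutions on the same aromatic ring, both of which stayed within the scatter. On that basis no step beyond the scatter is expected: a 1.2-fold lower number from compound 1 to compound 4 (0.07 log units; within the scatter). The value of compound 4 is estimated at 30000 nM, with a range from 12000 nM to 75000 nM.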

Compound 4, concentration for 50% growth inhibition: 29000 nM
Compound 4: middle estimate off by 1.0-fold (0.01 log units), on the high side, and the stated range covers the measured number.
By their numbers in this assay, from the lowest: compounds 3, 4, 2 and 1 (each within the scatter of the next).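

In this assay the step for methyl in place of hydrogen is a 1.2-fold lower number from compound 1 to compound 4 (0.08 log units; within the scatter) and so adds a carbon group to the two halogens as a change on this ring that stays within the scatter. It shows that this aromatic carbon, ortho to a fused ring and meta to a fused ring, accepts a methyl group with no readable change in the number. Nothing measured here offers an explanation for this result.

The compounds shown leave open whether an amine, a carboxylic acid or a longer chain on this carbon would give a step beyond the scatter.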